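The source may report more compounds than this note shows. Statements on the series, on what has been measured and on what is new or still open speak of the compounds shown alone.

Measured so far:
- compound 1, `N#CC1=C(NCN2CCCC2)N(c2ccccc2)C(=O)N2CCCCC(N3CCCC3)C12`, 22.9%
- compound 2, `N#CC1=C(NCC(=O)O)N(c2ccccc2)C(=O)N2CCCCC(N3CCCC3)C12`, 67.2%
- compound 3, `N#CC1=C(/N=C/Nc2ccc([N+](=O)[O-])cc2)N(c2ccccc2)C(=O)N2CCCCC(N3CCCC3)C12`, 32.1%

In a functional assay on the whole organism (strain albino) for inhibition, with Rattus norvegicus as the target, read by paw edema, with a stated time of 1 h, at a dose of 20 mmol/kg by the intraperitoneal route (a higher number here means more inhibition at the dose given (going by the name of the read-out), a lower number less inhibition), compound 3 stands second highest of the three numbers. Its nearest neighbour is compound 1, and the step of a number 9.2 percentage points higher from compound 1 to compound 3 (within the scatter) lies within the scatter, so no order between the two is claimed. Compound 2 stands furthest from it, and the step of a number 35.1 percentage points lower from compound 2 to compound 3 (beyond the scatter) is large and beyond the scatter.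

Compound 4, `N#CC1=C(NCC(=O)N2CCCC2)N(c2ccccc2)C(=O)N2CCCCC(N3CCCC3)C12`, has not yet been measured in this assay. It differs from compound 3 in one place: a group of 9 heavy atoms (6 carbon, 2 nitrogen, 1 oxygen; one five-membered non-aromatic ring with 1 hetero atom) in place of a group of 12 heavy atoms (7 carbon, 3 nitrogen, 2 oxygen; one six-membered aromatic ring of carbon only), on a double-bonded ring carbon

Going by the values given here, two measured steps bear on this change. The step of a number 44.3 percentage points higher from compound 1 to compound 2 (beyond the scatter) shows that a short chain ending in carboxy on the amine nitrogen gives a much higher number than a chain ending in pyrrolidin-1-yl. The step of a number 35.1 percentage points lower from compound 2 to compound 3 (beyond the scatter) shows that the nitroanilino group of compound 3 gives a much lower number than that carboxy chain. The entering group of compound 4 carries a pyrrolidin-1-yl on a carbonyl rather than directly on the chain carbon, and neither measured step covers exactly that arrangement. An upward step beyond the scatter from compound 3 is therefore expected, but smaller than the reverse of the step to compound 2, because the number of compound 1, 22.9%, shows a pyrrolidin-1-yl-bearing chain sitting low.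

For compound 4 the expected step is a number 14.9 percentage points higher from compound 3 to compound 4 (beyond the scatter), and the estimated value is 47%, with a range from 28% to 66%.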

Compound 4, a percentage reported as inhibition, in the whole organism at one dose (the size of the read-out at that dose, not a potency): 40.1%
Compound 4: the middle estimate sits 6.9 percentage points above what was measured, and the stated range covers the measured number.
By their numbers in this assay, from the lowest: compounds 1, 3 and 4 (each within the scatter of the next, the first and the last beyond it); then compound 2.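

In this assay, going by these compounds alone, exchanging the group of compound 3 for (((pyrrolidin-1-yl)carbonyl)methyl)amino on the double-bonded ring carbon gives a number 8 percentage points higher from compound 3 to compound 4 (within the scatter) and so establishes no order for this pair; two quite different groups at this position give numbers that cannot be told apart. The new information lies in the chain end, where a number 27.1 percentage points lower from compound 2 to compound 4 (beyond the scatter) sets pyrrolidin-1-yl in place of hydroxy on the carbonyl carbon, and a number 17.2 percentage points higher from compound 1 to compound 4 (beyond the scatter) sets (pyrrolidin-1-yl)carbonyl in place of pyrrolidin-1-yl on the saturated chain carbon, so the number depends both on the carbonyl and on what it carries. No measurement is at hand to explain these differences.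

Still open, from the compounds shown here alone, is whether the high number of compound 2 needs the free carboxylic acid or would survive in a methyl ester, and whether a longer chain carrying the carboxy would keep it. A dimethylamino group on the same carbonyl carbon would test whether compound 4 reflects the pyrrolidine ring in particular or any amine at that place.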